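The compounds below may be only part of what the source reports. "The series", "measured", "known", "first", "only" and "open" are said of these compounds alone.

Working notes on the series. Compound 1 `Cc1ccccc1S(=O)(=O)N[C@H]1CCN(CCCOc2ccc(C(=O)C3CC3)cc2)C1` is measured in an assay on isolated protein for binding affinity to histamine H2 receptor (Homo sapiens) (on this read-out higher numbers stand for weaker inhibition and lower numbers for stronger inhibition), at 2200 nM. Two other members of the series carry a different group on the nitrogen of the shared core. Compound 2 `CC(=O)c1ccc(OCCCN2CC[C@H](NC(=O)c3ccc(C#N)cc3)C2)cc1` gives 6100 nM in this assay, and compound 3 `O=C(N[C@H]1CCN(CCCOc2ccc(C(=O)C3CC3)cc2)C1)c1csc(-c2cccnc2)n1` gives 4000 nM. Compound 1 thus has the lowest of the three numbers; its gap to compound 3 is within the usual scatter, so no order between those two can be read, while its gap to compound 2 is beyond the scatter.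

Compound 4 `O=C(c1ccc(OCCCN2CC[C@H](NS(=O)(=O)c3ccccc3)C2)cc1)C1CC1` has not yet been measured. It differs from compound 1 in one place: hydrogen in place of methyl on an aromatic carbon. Cut one bond further out, the same difference reads 2-methylphenyl to phenyl, or (2-methylphenyl)sulfonyl to phenylsulfonyl. Among the measured compounds shown here, no pair of measured compounds in this set shows this kind of change, so there is no measured step to lean on; the three measured values give only the spread of the series so far. A single methyl removed from an aromatic carbon is a small change, and the step of a 1.4-fold higher number from compound 1 to compound 4 (0.13 log units; within the scatter) is expected to stay within the scatter, if anything toward a slightly higher number. Compound 4 is estimated at 3000 nM, with a range from 1200 nM to 8000 nM.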

Compound 4, inhibition constant: 1200 nM
Compound 4: the middle estimate sits 2.5-fold (0.40 log units) above what was measured; the range from low to high includes it.
By their numbers in this assay, from the lowest: compounds 4, 1, 3 and 2 (each within the scatter of the next, the first and the last beyond it).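

Among the compounds shown here, the first measured step at this position, hydrogen in place of methyl on an aromatic carbon ortho to a large group, reads a 1.8-fold lower number from compound 1 to compound 4 (0.26 log units; within the scatter) in this assay, so compound 1 and compound 4 cannot be placed in any order. For the compounds shown here, in this one pair, the 2-methylphenyl and phenyl forms of the sulfonyl group give values that cannot be told apart, and the methyl is not required to keep the number at this level, a point that the earlier compounds, with no step between them, could not address. Nothing available bears on why the two values lie so close, and this single pair cannot show whether the same would hold elsewhere in the series.

The compounds shown leave open whether a group other than methyl or hydrogen at the same place, such as methoxy, chlorine, an amine or a carboxylic acid, would give a step beyond the scatter. They also leave open whether the same exchange of methyl for hydrogen reads alike on a different sulfonyl group or with a methyl ketone in place of the cyclopropyl ketone.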